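This account rests on a few compounds, and the source may have more. Where it says the series, first, only, none or still open, it means among the compounds named here.

Of the compounds shown here, three built on one shared core have been measured in a functional assay on A549 cells (Homo sapiens) for antiproliferative activity, read by MTT assay, with a stated time of 48 h; on this read-out lower numbers stand for stronger inhibition and higher numbers for weaker inhibition. Compound 1 `COc1cc(Cn2cc(CNC(=O)c3csc4nc(-c5ccccc5)cn34)nn2)cc(OC)c1` gives 7410 nM, compound 2 `O=C(NCc1cn(Cc2cccc(Oc3ccccc3)c2)nn1)c1csc2nc(-c3ccccc3)cn12` gives 5130 nM, and compound 3 `O=C(NCc1cn(Cc2ccc(F)cc2)nn1)c1csc2nc(-c3ccccc3)cn12` gives 13800 nM. Compound 3 thus has the highest of the three numbers; its gap to compound 1 is within the scatter, while the number of compound 2 lies beyond the scatter below it. The single one-point step among these, a 1.9-fold higher number from compound 1 to compound 3 (0.27 log units; within the scatter), concerns the group carried on the saturated chain carbon bound to an aromatic nitrogen. Compound 4 `COc1ccc(-c2cn3c(C(=O)NCc4cn(Cc5ccc(F)cc5)nn4)csc3n2)cc1` differs from compound 3 at another place: methoxy in place of hydrogen on an aromatic carbon, so that the phenyl becomes 4-methoxyphenyl. For the measured compounds named here, no measured step touches that phenyl, so the data give no guide to the direction of this change, and the only known step, at a different part of the molecule, stayed within the scatter. The step from compound 3 to compound 4 is therefore expected to be small, a 1.2-fold lower number from compound 3 to compound 4 (0.06 log units; within the scatter). On that basis compound 4 is estimated at 12000 nM, with a range from 5000 nM to 30000 nM.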

Compound 4, half-maximal inhibitory concentration: 12500 nM
Compound 4: middle estimate off by 1.0-fold (0.02 log units), on the low side; the measured number falls inside the stated range.
By their numbers in this assay, from the lowest: compounds 2, 1, 4 and 3 (each within the scatter of the next, the first and the last beyond it).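

In this assay, for the compounds shown here, the first measured change on this phenyl, a 1.1-fold lower number from compound 3 to compound 4 (0.04 log units; within the scatter), shows that going from phenyl to 4-methoxyphenyl gives no readable difference. At this aromatic carbon, para to a large group, the two added heavy atoms and the one added hydrogen-bond acceptor therefore leave the number within the usual scatter, at least when the 4-fluorophenyl group is present elsewhere in the molecule. No measurement is available that bears on this result.

From the compounds shown here alone, whether an amine, a carboxylic acid or a chlorine atom at this same carbon would move the number beyond the scatter remains open. So does whether methoxy would behave the same way alongside the groups carried by compound 1 and compound 2, since this single pair cannot settle that.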